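Swapping an azidophenyl amide for a phenylpropyl amide

A few compounds are considered here, and "the series" means these few. Any claim that something is new, unique, unknown or untested is made for them only; others in the source may bear on it.

Compound 1 `N#CN/C(=N\CCCNc1ccccc1[N+](=O)[O-])NCCCCOc1cccc(CN2CCCCC2)c1` in a functional assay on cardiac atrium for antagonist activity at histamine H2 receptor (Cavia porcellus) (on this read-out lower numbers stand for lower potency and higher numbers for higher potency (the scale is a negative logarithm)), gives 7.85.
Compound 2 `N#CN/C(=N\CCNC(=O)c1ccc(N=[N+]=[N-])cc1)NCCCOc1cccc(CN2CCCCC2)c1` in this assay gives 7.9.
Compound 3 `N#CN/C(=N\CCNC(=O)c1ccccc1)NCCCCOc1cccc(CN2CCCCC2)c1` in this assay gives 7.67.

Among these three, compound 2 shows the highest number in this assay, but its distances to compound 1 and to compound 3 are both within the usual scatter, so no order among them can be claimed. Compound 4 `N#CN/C(=N\CCNC(=O)CCCc1ccccc1)NCCCOc1cccc(CN2CCCCC2)c1` has not yet been measured. It differs from compound 2 in one place: 3-phenylpropyl in place of 4-azidophenyl on a carbonyl carbon. Among the compounds with values here, the only measured single step that touches this end of the molecules is a number 0.18 log units lower from compound 1 to compound 3 (within the scatter), which exchanged the group hanging from the chain without moving the number beyond the scatter. Compound 4 keeps the amide link and the shared core. A small step is therefore expected, a number 0.30 log units lower from compound 2 to compound 4 (within the scatter). For compound 4 the estimate in this assay is 7.6, with a range from 7.1 to 8.1.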

Compound 4, negative logarithm of the antagonist equilibrium constant: 6.45
Estimate against measurement, compound 4: 1.15 log units above, outside the stated range (below it).
By their numbers in this assay, from the lowest: compound 4; then compounds 3, 1 and 2 (each within the scatter of the next).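

In this assay, this position proves sensitive: 3-phenylpropyl in place of 4-azidophenyl on a carbonyl carbon gives a number 1.45 log units lower from compound 2 to compound 4 (beyond the scatter). The earlier step, a number 0.18 log units lower from compound 1 to compound 3 (within the scatter), gave no sign of this. Both groups count the same heavy atoms and one six-membered aromatic ring of carbon only, so those counts alone do not set the number.

Nothing shown explains the drop. On these data alone, whether it follows the flexible chain or the lost azide stays open, and 2-phenylethyl or 4-aminophenyl on the same carbonyl carbon would help separate the two.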